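The compounds below may be only part of what the source reports. "The series", "measured", "known", "first", "only" and "open" are said of these compounds alone.

Measured compounds:
- compound 1, `O=C1c2c[n+]([O-])c3ccccc3c2C(=O)c2c1c1ccccc1n2Cc1cn([C@H]2C[C@H](O)[C@@H](CO)O2)nn1`, gives 120 nM in a functional assay on HCT-116 cells (Homo sapiens) for cytotoxicity, read by MTT assay, with a stated time of 72 h; a lower number here means a stronger inhibitor, a higher number a weaker inhibitor
- compound 2, `CC1(C)OCC(Cn2cc(Cn3c4c(c5ccccc53)C(=O)c3c[n+]([O-])c5ccccc5c3C4=O)nn2)O1`, gives 70 nM in this assay
- compound 3, `CN(C)CCCCn1c2c(c3ccccc31)C(=O)c1c[n+]([O-])c3ccccc3c1C2=O`, gives 450 nM in this assay

Compound 2 has the lowest number of the three in this assay. Its nearest neighbour is compound 1, and that pair differs by a 1.7-fold lower number from compound 1 to compound 2 (0.23 log units; within the scatter), which is within the scatter, so the two cannot be set in order. Compound 3 sits clearly higher than compound 2, beyond the scatter.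

Compound 4, `CC1(C)OC[C@@H](Cn2cc(Cn3c4c(c5ccccc53)C(=O)c3c[n+]([O-])c5ccccc5c3C4=O)nn2)O1`, is the next compound in the series. It differs from compound 2 as follows: the two compounds have the same atoms and bonds; at least one stereo element is drawn with a configuration in one of them and without one in the other: 1 of 1 stereo elements differ; a stereocentre at a saturated ring carbon is drawn without a configuration in compound 2 and R in compound 4. Compound 2 is drawn as a mixture at that ring carbon, while compound 4 is one single drawn configuration of the same atoms and bonds.

Among the compounds with values here, no measured step concerns a stereocentre; the one step between neighbouring compounds, from compound 1 to compound 2, swaps one group for another and gives no guidance on separating configurations. Within the data shown here, the number for compound 2 already contains whatever the single configuration of compound 4 contributes. The expected step of no change at the digits printed from compound 2 to compound 4 (within the scatter) is therefore none beyond the scatter. Compound 4 is estimated at 70 nM in this assay, with a range from 30 nM to 160 nM.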

Compound 4, half-maximal inhibitory concentration: 340 nM
Compound 4: the middle estimate sits 4.9-fold (0.69 log units) below what was measured; the measured number lies above the stated range.
By their numbers in this assay, from the lowest: compounds 2 and 1 (each within the scatter of the next); then compounds 4 and 3 (each within the scatter of the next).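

Setting the ring carbon to R in this assay gives a 4.9-fold higher number from compound 2 to compound 4 (0.69 log units; beyond the scatter), the first step in this series that touches a stereocentre, and it shows that this carbon of the (2,2-dimethyl-1,3-dioxolan-4-yl)methyl group matters, since nothing else separates the pair: the fact that one of compounds 2 and 4 is drawn with a defined configuration and the other without, at the place where they differ

If compound 2 is the mixture it is drawn as, the R form does not account for its number, which points to the other configuration as the likelier source of the lower value. The swap of groups also reads differently now: compound 1 and compound 2 could not be set in order, yet the same swap with the R form gives a 2.8-fold higher number from compound 1 to compound 4 (0.45 log units; beyond the scatter), so any comparison of these two groups depends on the configuration at that carbon.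

The S form at that ring carbon lies outside the compounds shown, so its number, and whether it alone explains compound 2, remain open. Also open, going by these compounds, is whether a 2,3-dihydroxypropyl group in place of the (2,2-dimethyl-1,3-dioxolan-4-yl)methyl group would depend on configuration in the same way.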